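A Methoxy for Chloro Swap Against Cell Toxicity

The source may hold more compounds than are shown below. What is called first, only, known or untested is meant among the compounds shown, and "the series" means these compounds.

In an ADME assay on SH-SY5Y cells (Homo sapiens) for cytotoxicity, read by MTT assay, with a stated time of 72 h (on this read-out higher numbers stand for weaker inhibition and lower numbers for stronger inhibition), compound 1 `O=C(CN1CCN(C(=O)c2cccc(Cl)c2)CC1)N1CCN(CCCc2c[nH]c3ccccc23)CC1` gives 120000 nM. Compound 2 `COc1cccc(C(=O)N2CCN(CC(=O)N3CCN(CCCc4c[nH]c5ccccc45)CC3)CC2)c1` reaches only (the limit of > 200000 nM in this assay, at which 1 of the 3 values shown sits), so for compound 2 the value > 200000 nM is a limit of the assay and not a number. The two differ by methoxy in place of chloro on an aromatic carbon, and the step was an at least 1.6-fold higher number from compound 1 to compound 2 (0.22 log units; that floor lies within the scatter). Compound 3 `O=C(CN1CCN(C(=O)c2cccc(Cl)c2)CC1)N1CCN(CCCc2c[nH]c3ccc(F)cc23)CC1` differs from compound 1 by fluoro in place of hydrogen on an aromatic carbon, and in this assay compound 3 gives 59800 nM, a step of a 2.0-fold lower number from compound 1 to compound 3 (0.30 log units; within the scatter).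

Compound 4 `COc1cccc(C(=O)N2CCN(CC(=O)N3CCN(CCCc4c[nH]c5ccc(F)cc45)CC3)CC2)c1` has not yet been measured. It differs from compound 3 by methoxy in place of chloro on an aromatic carbon, the same change as from compound 1 to compound 2, made on the same place of the ring. The cores of compound 3 and compound 4 carry the fluoro described above, which the cores of compound 1 and compound 2 lack.

From compound 3 to compound 4 the expected step is a 2.5-fold higher number from compound 3 to compound 4 (0.40 log units; beyond the scatter), resting on the earlier at least 1.6-fold higher number from compound 1 to compound 2 (0.22 log units; that floor lies within the scatter), which only set a floor. Compound 4 is therefore estimated at 150000 nM, with a range from 60000 nM to 300000 nM.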

Compound 4, half-maximal inhibitory concentration: 79400 nM
Compound 4: middle estimate off by 1.9-fold (0.28 log units), on the high side; measured number inside the range.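

Carried to the core that bears the fluoro, methoxy in place of chloro gives a 1.3-fold higher number from compound 3 to compound 4 (0.12 log units; within the scatter) in this assay, a step small enough to say little on its own, and the comparison with the first core stays loose: the same change on two cores in this assay, an at least 1.6-fold higher number (0.22 log units; that floor lies within the scatter) from compound 1 to compound 2 and a 1.3-fold higher number (0.12 log units; within the scatter) from compound 3 to compound 4; the limit leaves it open whether they differ. The fluoro change, read on the methoxy pair, gives an at least 2.5-fold lower number from compound 2 to compound 4 (0.40 log units; beyond the scatter), and this too can be set only loosely beside the same change on the chloro pair: the same change on two cores in this assay, a 2.0-fold lower number (0.30 log units; within the scatter) from compound 1 to compound 3 and an at least 2.5-fold lower number (0.40 log units; beyond the scatter) from compound 2 to compound 4; the limit leaves it open whether they differ. Compound 2 stands at a limit of the assay and not at a number, so these pairs neither prove that either change carries over from one core to the other with the same size nor show that it does not.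

Still open, going by these compounds, is how an amine or a nitrile in place of the chloro would read in this assay. Also open, on these data alone, is whether either change would behave the same way on a core with a longer chain.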